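The source may report more compounds than this note shows. Statements on the series, on what has been measured and on what is new or still open speak of the compounds shown alone.

Compound 1, `Clc1nc(NC2CC2)c2ncn(C3CCCCO3)c2n1`, gives 11.9% in a functional assay on the whole organism with Mus musculus as the target, with a stated time of 90 min, at a dose of 25 umol/kg by the oral route; a lower number here means a weaker effect, a higher number a stronger effect of the compound at the dose given.
Compound 2, `CCOC(=O)CN(c1nc(Cl)nc2c1ncn2C1CCCCO1)C1CC1`, gives 13%.
Compound 3, `O=C(CN(c1nc(Cl)nc2c1ncn2C1CCCCO1)C1CC1)N[C@@H](CCC(=O)OCc1ccccc1)C(=O)OCc1ccccc1`, gives 25.2%.

Compound 3 stands highest of these three numbers; compound 2 and compound 1 both lie lower, each beyond the scatter. Compound 4, `CSCC[C@H](NC(=O)CN(c1nc(Cl)nc2c1ncn2C1CCCCO1)C1CC1)C(=O)OCc1ccccc1`, has not yet been measured in this assay. It differs from compound 3 in one place: methylsulfanyl in place of benzyloxycarbonyl on a saturated chain carbon, three bonds along the chain from an amide-type nitrogen and a carbonyl carbon. Cut one bond further out, the same difference reads 2-(benzyloxycarbonyl)ethyl to 2-(methylsulfanyl)ethyl.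

Going by the values given here, only one single-change step has been measured, a number 1.1 percentage points higher from compound 1 to compound 2 (within the scatter), and it concerns a different part of the shared core, so it says nothing about this change. Compound 2 and compound 3 differ in more than one place; their values show compound 3 higher by a margin beyond the scatter, but that does not isolate the change at hand. Among the compounds with values here, with no directly relevant step, the expected step is a number 5.2 percentage points lower from compound 3 to compound 4 (within the scatter), a modest drop with wide uncertainty. Compound 4 is therefore estimated at 20%, expected to fall between 8% and 34%.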

Compound 4, a percentage reported as activity, at one dose (the size of the read-out at that dose, not a potency): 42.7%
Beside the measured number, compound 4's estimate is 22.7 percentage points below it, and the stated range ends below it.
By their numbers in this assay, from the lowest: compounds 1 and 2 (each within the scatter of the next); then compound 3; then compound 4.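

Going by these compounds alone, replacing benzyloxycarbonyl with methylsulfanyl on this saturated chain carbon leads to a number 17.5 percentage points higher from compound 3 to compound 4 (beyond the scatter) in this assay, so this is the first measured single change at this position, and it goes upward beyond the scatter. The benzyloxycarbonyl group, with its 10 heavy atoms and six-membered aromatic ring, is therefore not needed here for the effect at this dose, since methylsulfanyl, with only 2 heavy atoms and no ring, gives a higher number. No measurement on hand gives a reason for this rise.

The compounds shown leave open whether a plain alkyl chain without sulfur, a longer chain ending in methylsulfanyl, a carboxylic acid or an amine at the same place would keep this gain. Nor do they show whether the sulfur itself matters, which a methoxy group in place of methylsulfanyl would test.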